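A few compounds are considered here, and "the series" means these few. Any claim that something is new, unique, unknown or untested is made for them only; others in the source may bear on it.

Compound 1 `Cc1cccc(-c2noc(C3CN(S(=O)(=O)c4cccc(C)c4)C3)n2)c1` reaches only a limit in an assay on HEK293 cells for positive allosteric modulation of metabotropic glutamate receptor 5 (Homo sapiens), read by FLIPR (on this read-out lower numbers stand for an effect already at smaller amounts and higher numbers for an effect only at larger amounts of compound), > 10000 nM. Compound 2 `O=C(N1CCC(F)CC1)N1CC(c2nc(-c3cccc(Cl)c3)no2)C1` gives 990 nM in this assay. For compound 3 `O=C(C1CCCO1)N1CC(c2nc(-c3cccc(Cl)c3)no2)C1` the result in this assay is again only a limit, > 10000 nM. Compound 3 therefore stands at the limit of > 10000 nM in this assay, at which 2 of the 3 values shown sit, with no number of its own. Compound 4 `CC1CCN(C(=O)N2CC(c3nc(-c4cccc(Cl)c4)no3)C2)C1` differs from compound 3 by 3-methylpyrrolidin-1-yl in place of oxolan-2-yl on a carbonyl carbon. Among the compounds with values here, the one measured step that bears on this change is an at least 10-fold higher number from compound 2 to compound 3 (1.00 log units; beyond the scatter), which ran in the opposite sense: the 4-fluoropiperidin-1-yl group on the carbonyl gave way to oxolan-2-yl. Compound 4 restores a nitrogen-linked five-membered ring on that carbonyl, so a move back toward smaller numbers, an at least 6.6-fold lower number from compound 3 to compound 4 (0.82 log units; beyond the scatter), is expected. Compound 4 is accordingly estimated at 1500 nM, within a range of 500 nM to 8000 nM.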

Compound 4, half-maximal effective concentration: > 10000 nM
Compound 4 gave a limit, no number (the forecaster's own chance of this, stated with the estimate: 25%); at least 6.6-fold (0.82 log units) between middle value and limit.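

In this assay the 3-methylpyrrolidin-1-yl group on the carbonyl carbon does not match 4-fluoropiperidin-1-yl, with an at least 10-fold higher number from compound 2 to compound 4 (1.00 log units; beyond the scatter) showing that a nitrogen-linked ring on that carbonyl is not sufficient in itself. The change from oxolan-2-yl to 3-methylpyrrolidin-1-yl cannot be read, as compound 3 and compound 4 both end in limits. Only compound 2 gives a number, and the other compounds share one ceiling: the limit of > 10000 nM in this assay, at which 3 of the 4 values shown sit. Still open, from the compounds shown here alone, is whether the piperidine ring or the fluorine of compound 2 carries its value. An unsubstituted piperidin-1-yl or a morpholin-4-yl on the carbonyl would separate the two.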